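The source may report more compounds than this note shows. Statements on the series, on what has been measured and on what is new or still open speak of the compounds shown alone.

Of the compounds shown here, three have been measured in an ADME assay on microsomes from liver (Homo sapiens) for metabolic stability, tested at 2.5 uM; on this read-out higher numbers stand for fast clearance and lower numbers for slow clearance. Compound 1 `COc1cccc(-c2c(S(=O)(=O)c3ccc(OC)c(Cl)c3)cnc3cc(F)ccc23)c1` gives 1.71 mL/min, and compound 3 `COc1ccc(S(=O)(=O)c2cnc3cc(F)ccc3c2-c2cccc(F)c2)cc1Cl` gives 2.08 mL/min. These two differ in one place, (fluoro in place of methoxy on an aromatic carbon), and the resulting step, a 1.2-fold higher number from compound 1 to compound 3 (0.09 log units; within the scatter), lies within the scatter of the measurement. Compound 2 `COc1ccc(S(=O)(=O)c2cnc3c(F)cccc3c2-c2cccc(F)c2)cc1` gives 3.03 mL/min in this assay. How the core of compound 2 differs from the core of compound 1 is not broken down here; the gap between the two values lies within the scatter, as does the gap between compound 2 and compound 3, so no order among the three can be read from these numbers.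

Compound 4 `O=S(=O)(c1ccc(F)cc1)c1cnc2c(F)cccc2c1-c1cccc(F)c1` has not yet been measured in this assay. It differs from compound 2 in one place, (fluoro in place of methoxy on an aromatic carbon). Going by the values given here, this is the same kind of change as the one from compound 1 to compound 3, but not the same change: in compound 1 the group that leaves sits meta to a large group, whereas in compound 2 it sits para to a large group. With a single measured example of this kind of change, the expectation rests on that one example and on the starting point. The step is expected to be a 1.1-fold higher number from compound 2 to compound 4 (0.05 log units; within the scatter), because a 1.2-fold higher number from compound 1 to compound 3 (0.09 log units; within the scatter) was a small step and compound 2 starts from 3.03 mL/min. Compound 4 is therefore expected to give about 3.4 mL/min, with a likely range from 1.8 mL/min to 6.5 mL/min.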

Compound 4, intrinsic clearance in a liver preparation (reported as CLH), per the amount of preparation that the assay uses: 1.56 mL/min
The estimate for compound 4 lay 2.2-fold (0.34 log units) above the measured number, outside the stated range (below it).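

The change from 4-methoxyphenyl to 4-fluorophenyl gives, in this assay, a 1.9-fold lower number from compound 2 to compound 4 (0.29 log units; within the scatter). Set beside the earlier step of the same kind, it does not differ from that step by more than the measurement can resolve: the same change on two cores in this assay, a 1.2-fold higher number (0.09 log units; within the scatter) from compound 1 to compound 3 and a 1.9-fold lower number (0.29 log units; within the scatter) from compound 2 to compound 4, 2.4-fold (0.37 log units) apart, within the scatter of two such steps. Going by these compounds alone, the pair therefore gives no sign that fluoro in place of methoxy behaves differently on the two cores, but it does not prove that the change carries over unaltered either, as each step alone lies within the scatter and only two cores are compared.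

The compounds shown leave open how an amine, a carboxylic acid or a longer chain in place of methoxy would read in this assay. They also leave open whether fluoro in place of methoxy would stay within the scatter on further cores, and whether any single change in this series gives a step beyond it.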